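The compounds below may be only part of what the source reports. "The series", "measured", "known", "first", "only" and "open" are said of these compounds alone.

Working notes on the series. In an ADME assay on MT4 cells (Homo sapiens) for cytotoxicity, read by MTT assay, with a stated time of 5 days (on this read-out higher numbers stand for lower toxicity in this test and lower numbers for higher toxicity in this test), compound 1 `COc1cc(Cc2cnc(/N=C3\C(=O)N(CN4CCC(C)CC4)c4ccc(Cl)cc43)nc2N)cc(OC)c1OC` gives 67.4 ug/mL, the highest of the two numbers in hand. Compound 2 `COc1cc(Cc2cnc(/N=C3\C(=O)N(CN4CCN(c5ccc(F)cc5)CC4)c4ccc(Cl)cc43)nc2N)cc(OC)c1OC` gives 65.6 ug/mL in this assay, which sits within the scatter of compound 1, so no order between the two is claimed. Compound 3 `CCN(CC)CN1C(=O)/C(=N\c2ncc(Cc3cc(OC)c(OC)c(OC)c3)c(N)n2)c2cc(Cl)ccc21` has not yet been measured in this assay. It differs from compound 1 by diethylamino in place of 4-methylpiperidin-1-yl on a saturated chain carbon bound to an amide-type nitrogen in a ring. Among the measured compounds shown here, no measured pair shows this change. The expected step of a 1.1-fold lower number from compound 1 to compound 3 (0.04 log units; within the scatter) in this assay is therefore none beyond the scatter, in either direction. Compound 3 is estimated at 62 ug/mL, with a range from 30 ug/mL to 125 ug/mL.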

Compound 3, half-maximal cytotoxic concentration: 79.1 ug/mL
The estimate for compound 3 lay 1.3-fold (0.11 log units) below the measured number; measured number inside the range.
By their numbers in this assay, from the lowest: compounds 2, 1 and 3 (each within the scatter of the next).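

In this assay, diethylamino in place of 4-methylpiperidin-1-yl gives a 1.2-fold higher number from compound 1 to compound 3 (0.07 log units; within the scatter). At this place, on a saturated chain carbon bound to an amide-type nitrogen in a ring, an open-chain amine therefore reads the same as the ring-bearing amine within the scatter, so the ring of 4-methylpiperidin-1-yl is not required to hold the number at this level. Nothing available bears on why the step is this small.

Still open, on these data alone, is whether any group here moves the number beyond the scatter. A morpholin-4-yl group, a primary amine or a carboxylic acid at this place would test that.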